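This account rests on a few compounds, and the source may have more. Where it says the series, first, only, none or still open, it means among the compounds named here.

Measured compounds in a functional assay on K562 cells (Homo sapiens) for cytotoxicity, read by CCK-8 assay, with a stated time of 72 h; on this read-out higher numbers stand for weaker inhibition and lower numbers for stronger inhibition:
Compound 1, `C=CCn1c(=O)/c(=C\c2ccccc2F)[nH]c(=O)/c1=C\c1ccccc1OC`, gives 5600 nM.
Compound 2, `C=CCn1c(=O)/c(=C\c2ccc(C)cc2)[nH]c(=O)/c1=C\c1ccccc1OC`, gives "not active" (no number reported).
Compound 3, `C=CCn1c(=O)/c(=C\c2ccccc2C(F)(F)F)[nH]c(=O)/c1=C\c1ccccc1OC`, gives 2700 nM.

Compound 3 holds the lowest of the two numbers reported in this assay; its nearest neighbour is compound 1, and the step of a 2.1-fold lower number from compound 1 to compound 3 (0.32 log units; beyond the scatter) is beyond the scatter, while compound 2 is reported without a number at all. Compound 4, `C=CCn1c(=O)/c(=C\c2ccccc2Cl)[nH]c(=O)/c1=C\c1ccccc1OC`, differs from compound 3 in one place: chloro in place of trifluoromethyl on an aromatic carbon. Within the data shown here, only one measured step bears on this change, namely a 2.1-fold lower number from compound 1 to compound 3 (0.32 log units; beyond the scatter), which shows a modest lowering when a single halogen gives way to the larger trifluoromethyl group on this ring. Chloro sits between those two groups in what is counted, so compound 4 is expected to land between compound 1 and compound 3, and the expected step of a 1.4-fold higher number from compound 3 to compound 4 (0.15 log units; within the scatter) is a modest rise in the number that may not clear the scatter. Among the measured compounds shown here, compound 4 is therefore estimated at 3800 nM in this assay, with a range from 1600 nM to 9000 nM, resting on the single step from compound 1 to compound 3 and on nothing else.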

Compound 4, half-maximal inhibitory concentration: 2500 nM
The estimate for compound 4 lay 1.5-fold (0.18 log units) above the measured number; low and high end bracket the measured number.
By their numbers in this assay, from the lowest: compounds 4 and 3 (each within the scatter of the next); then compound 1.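

In this assay, exchanging trifluoromethyl for chloro on this aromatic carbon gives a 1.1-fold lower number from compound 3 to compound 4 (0.03 log units; within the scatter), so a single chlorine atom can stand in for the whole trifluoromethyl group here without a change that can be told from the scatter. The earlier step from fluoro to trifluoromethyl might have suggested that the number falls as the group grows, but the chloro result does not follow that trend: a 2.2-fold lower number from compound 1 to compound 4 (0.35 log units; beyond the scatter) is a step of about the same modest size, which leaves fluoro apart from the other two groups at this place, with chloro and trifluoromethyl level with each other. Nothing available on these compounds accounts for this grouping or for the similarity of chloro and trifluoromethyl.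

The compounds shown leave open how other groups would behave on this same aromatic carbon, such as a bromine atom, a nitrile, an amine or a carboxylic acid, and so whether any group here goes beyond the level that chloro and trifluoromethyl share. They also leave open whether the gap between fluoro and chloro would persist with a longer chain in place of the one on the nitrogen of the shared core.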